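The source may hold more compounds than are shown below. What is called first, only, known or untested is meant among the compounds shown, and "the series" means these compounds.

Working notes on the series. In a functional assay on the whole organism for inhibition, with Rattus norvegicus as the target (on this read-out lower numbers stand for an effect already at smaller amounts and higher numbers for an effect only at larger amounts of compound), compound 1 `COc1ccccc1CC(Oc1ccc(C(C)C)cc1)C(=O)O` gives > 10 mg/kg, which is a limit and not a number. Among the measured compounds shown here, compound 2 `CCc1ccc(CC(C)(Oc2ccc(C(C)C)cc2)C(=O)O)cc1` gives 0.1 mg/kg, the only actual number so far. Compound 3 `COc1ccccc1CC(C)(Oc1ccc(C(C)C)cc1)C(=O)O` carries 2-methoxyphenyl in place of 4-ethylphenyl on a saturated chain carbon, two bonds along the chain from a carbonyl carbon and an oxygen on an aromatic ring. For the measured compounds named here, no measured step covers this change, so the expectation is tentative: a loss beyond the scatter in this assay, towards larger doses. The expected size is a 10-fold higher number from compound 2 to compound 3 (1.00 log units; beyond the scatter). Compound 3 is estimated at 1 mg/kg, with an expected range of 0.2 mg/kg to 8 mg/kg.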

Compound 3, dose for half-maximal effect: > 10 mg/kg
Compound 3: a limit, no number (the forecaster's own chance of this, stated with the estimate: 20%); middle value at least 10-fold (1.00 log units) away from the limit.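

In this assay, 2-methoxyphenyl in place of 4-ethylphenyl on this saturated chain carbon gives an at least 100-fold higher number from compound 2 to compound 3 (2.00 log units; beyond the scatter), so the activity of compound 2 does not survive this exchange of aryl groups. Going by these compounds, the true size of this step stays unknown, as the result for compound 3 is a limit: the limit of > 10 mg/kg in this assay, at which 2 of the 3 values shown sit. The step from compound 1 to compound 3 cannot be read, as both results are limits, so the effect of the added methyl remains unseen with 2-methoxyphenyl in place.

The compounds shown leave open whether the loss follows the removal of ethyl or the arrival of methoxy. A 4-methoxyphenyl or 2-ethylphenyl group at this carbon would separate the two, and the hydrogen analogue of compound 2 would test the methyl.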